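From 3,4-dichlorophenyl to 4-bromophenyl in a growth assay

The source may report more compounds than this note shows. Statements on the series, on what has been measured and on what is new or still open speak of the compounds shown alone.

Compound 1 `O=S(=O)(/C=C/c1ccccc1)Cc1ccc(Nc2ncnc3ccccc23)cc1` gives > 100000 nM as a limit
Compound 2 `N#Cc1ccc(/C=C/S(=O)(=O)Cc2ccc(Nc3ncnc4ccccc34)cc2)cc1` gives > 100000 nM as a limit
Compound 3 `O=S(=O)(/C=C/c1ccc(Cl)c(Cl)c1)Cc1ccc(Nc2ncnc3ccccc23)cc1` gives 11000 nM as a number

All three compounds were tested in a functional assay on U-251 cells (Homo sapiens) (on this read-out lower numbers stand for stronger inhibition of growth and higher numbers for weaker inhibition of growth), and share one core. Going by the values given here, compound 3 is the only one that gives a number here. Compound 1 and compound 2 rest on the limit of > 100000 nM in this assay, at which 2 of the 3 values shown sit, and neither gives a number.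

Compound 4 `O=S(=O)(/C=C/c1ccc(Br)cc1)Cc1ccc(Nc2ncnc3ccccc23)cc1` has not yet been measured. It carries 4-bromophenyl in place of 3,4-dichlorophenyl on a double-bonded chain carbon bound to a double-bonded chain carbon on a double-bonded chain carbon bound to a double-bonded chain carbon.

Among the compounds with values here, two measured steps bear on this change. On these data alone, one is an at least 9.0-fold lower number from compound 1 to compound 3 (0.95 log units; beyond the scatter) and the other is an at least 9.0-fold lower number from compound 2 to compound 3 (0.95 log units; beyond the scatter) and each starts from a limit, so its true size stays open. Neither step involves 4-bromophenyl, and a step that the two limits leave unreadable from compound 1 to compound 2 adds nothing that can be sized.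

With compound 3 at 11000 nM as the only anchor, some of its advantage is expected to be lost. Compound 4 may also reach the limit. The expected change is a 2.7-fold higher number from compound 3 to compound 4 (0.44 log units; beyond the scatter) toward weaker inhibition of growth. Compound 4 is estimated at 30000 nM (from 8000 nM to 100000 nM).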

Compound 4, concentration for 50% growth inhibition: > 100000 nM
Compound 4: only a limit was reported; the forecaster's own chance of this, stated with the estimate: 35%; middle value at least 3.3-fold (0.52 log units) from the limit.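

In this assay, replacing 3,4-dichlorophenyl with 4-bromophenyl on a double-bonded chain carbon bound to a double-bonded chain carbon gives an at least 9.0-fold higher number from compound 3 to compound 4 (0.95 log units; beyond the scatter), so the number held by compound 3 does not carry over to this other halogen-bearing phenyl. Compound 1 and compound 2 had shown only that phenyl and 4-cyanophenyl leave no number; compound 4 now shows that a halogen on this phenyl is not enough in itself, and compound 3 remains the only compound with a number, the others resting on one shared bound: the limit of > 100000 nM in this assay, at which 3 of the 4 values shown sit. Compound 4 gives > 100000 nM, which is a limit and not a number, and its steps to compound 1 and compound 2 cannot be read.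

The compounds shown do not separate the kind of halogen from the number of halogens, so it stays open whether a phenyl carrying one chlorine or two bromines would give a number. On these data alone, it is also open how far compound 1, compound 2 and compound 4 differ beyond the limit, and how an amine or a carboxylic acid on this phenyl would read.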